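One Methyl More on a Short-Lived Compound

A few compounds are considered here, and "the series" means these few. Any claim that something is new, unique, unknown or untested is made for them only; others in the source may bear on it.

In an ADME assay (on this read-out lower numbers stand for a shorter-lived compound and higher numbers for a longer-lived compound), compound 2 `CCOc1cc(OC)ccc1C[S+]([O-])c1ncccc1C(=O)Nc1ccncc1` gives only a limit, < 0.02 h. Compound 3 `COc1ccc(C[S+]([O-])c2ncccc2C(=O)Nc2ccncc2)c(OC)c1` also gives only a limit, < 0.02 h. Compound 1 `COc1cc(OC)c(C[S+]([O-])c2ncccc2C(=O)Nc2ccncc2)cc1Br` gives a number, 0.07 h. Compound 2 thus stands at the limit of < 0.02 h in this assay, at which 2 of the 3 values shown sit.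

Compound 4 `CCOc1ccc(C[S+]([O-])c2ncccc2C(=O)Nc2ccncc2)c(OCC)c1` differs from compound 2 by methyl in place of hydrogen on a saturated chain carbon bound to an oxygen on an aromatic ring, turning methoxy to ethoxy. The closest measured change is the same kind of swap in reverse, a step that the two limits leave unreadable from compound 2 to compound 3, so it gives no size to carry over. The other measured change, an at least 3.5-fold lower number from compound 1 to compound 3 (0.54 log units; beyond the scatter), concerns bromo and bears only indirectly. No shift beyond the scatter is therefore expected, and the estimated step is a step that the limit leaves unreadable from compound 2 to compound 4. For compound 4 the expected half-life is 0.015 h, within an estimated range of 0.007 h to 0.04 h.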

Compound 4, half-life: < 0.02 h
Compound 4 was reported as a limit (the forecaster's own chance of this, stated with the estimate: 75%); the middle value does not contradict the limit.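

In this assay compound 4 gives only a limit, < 0.02 h. Compound 2 is also a limit, and no step can be read between compound 2 and compound 4. The compounds shown leave open whether methoxy to ethoxy shifts the half-life at all.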